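Chain shortening in a fluoroindole alkanamide pair

The compounds below may be only part of what the source reports. "The series", "measured", "known", "first", "only" and "open" are said of these compounds alone.

Measured so far:
- compound 1 `NC(=O)CCCCc1c[nH]c2ccc(F)cc12`: 39 nM in an assay on isolated protein (urine) for inhibition of Myeloperoxidase (Homo sapiens), with a stated time of 5 min; on this read-out higher numbers stand for weaker inhibition and lower numbers for stronger inhibition
- compound 2 `NC(=O)CCc1c[nH]c2c(F)cccc12`: 271 nM in this assay

Compound 1 holds the lower of the two numbers; compound 2 stands well above it, beyond the usual scatter. The two differ in more than one place, so no single step can be read from them.

Compound 3 `NC(=O)CCCc1c[nH]c2ccc(F)cc12` has not yet been measured in this assay. It differs from compound 1 in one place only: carbamoyl in place of carbamoylmethyl on a saturated chain carbon, three bonds along the chain from an aromatic carbon. No measured pair isolates this shortening of the chain, so the direction of the step is open; the only shorter-chain compound shown, compound 2, also carries its fluorine elsewhere and gives a higher number.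

The step from compound 1 to compound 3 is expected to be modest, more likely toward a higher number, as a 2.1-fold higher number from compound 1 to compound 3 (0.31 log units; beyond the scatter). Compound 3 is expected to give 80 nM, within a range from 25 nM to 300 nM.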

Compound 3, half-maximal inhibitory concentration: 18 nM
Compound 3: the middle estimate sits 4.4-fold (0.65 log units) above what was measured, and the stated range ends above it.
By their numbers in this assay, from the lowest: compound 3; then compound 1; then compound 2.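

With the fluorine held in place, carbamoyl in place of carbamoylmethyl on this saturated chain carbon gives a 2.2-fold lower number from compound 1 to compound 3 (0.34 log units; beyond the scatter) in this assay and so moves toward stronger inhibition, beyond the scatter. For the compounds shown here, this is the first change at this position that can be read on its own, as compound 2 also carries its fluorine elsewhere and adds no second point to this step. Nothing at hand bears on why the shorter chain gives the lower number.

Open, going by these compounds, is whether the primary amide end at this place on the chain can give way to a carboxylic acid or a nitrile. Also open, on these data alone, are how much further the chain can shorten with the fluorine kept as in compound 3, and what the location of the fluorine contributes on a chain of unchanged length.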